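The source may report more compounds than this note shows. Statements on the series, on what has been measured and on what is new or still open speak of the compounds shown alone.

In a functional assay on MCF7 cells (Homo sapiens) for antiproliferative activity, read by MTT assay, with a stated time of 48 h (on this read-out lower numbers stand for stronger inhibition and higher numbers for weaker inhibition), two compounds built on a shared core have been measured so far. Compound 1 `Cc1ccc(-c2cc(NC(=O)/C=C/c3ccc(Cl)cc3)n[nH]2)cc1` gives 1190 nM, and compound 2 `O=C(/C=C/c1ccc(Cl)cc1)Nc1cc(-c2ccccc2)[nH]n1` gives 970 nM. These two values lie within the usual scatter of repeated measurements, so compound 2 cannot be ranked above or below compound 1.

The next compound, compound 3 `Cc1ccc(/C=C/C(=O)Nc2cc(-c3ccccc3)[nH]n2)cc1`, keeps everything in compound 2 except one group: methyl in place of chloro on an aromatic carbon. This is methyl in place of chloro on an aromatic carbon, or 4-chlorophenyl to 4-methylphenyl. Going by the values given here, only one measured step offers any guide, and only a loose one: a 1.2-fold lower number from compound 1 to compound 2 (0.09 log units; within the scatter). That step is hydrogen in place of methyl on an aromatic carbon, at another place in the molecule, and it stayed within the scatter. Among the compounds with values here, no measured pair changes the chloro itself, so the evidence is thin. On that basis, no step beyond the scatter is expected, and the expected step is a 1.2-fold higher number from compound 2 to compound 3 (0.09 log units; within the scatter). The estimate for compound 3 in this assay is 1200 nM, with an expected range of 550 nM to 2800 nM.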

Compound 3, half-maximal inhibitory concentration: 1780 nM
Estimate against measurement, compound 3: 1.5-fold (0.17 log units) below, within the range that was stated.
By their numbers in this assay, from the lowest: compounds 2, 1 and 3 (each within the scatter of the next).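

In this assay the swap of chloro for methyl gives a 1.8-fold higher number from compound 2 to compound 3 (0.26 log units; within the scatter) and so stays within what repeated measurements would scatter by, with one heavy atom leaving and one entering. Going by these compounds alone, the earlier step lay at another place in the molecule, so this is the first reading at this position itself, and it shows that compound 3, which carries no chlorine at all, cannot be told apart from compound 2 on this read-out. No measurement of any property of these groups accompanies the result, so the data offer no explanation for the size of this step.

The compounds shown leave open whether any group at this position would move the number beyond the scatter, and a fluoro, a methoxy, an amine or a carboxylic acid in place of the chloro would each put that question to a different kind of group. As far as these compounds go, with only hydrogen, methyl and chloro seen at the two places changed so far, the reach of either place on this read-out also remains unknown.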